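Compound 1 to compound 4: adding a substituted phenyl

A few compounds are considered here, and "the series" means these few. Any claim that something is new, unique, unknown or untested is made for them only; others in the source may bear on it.

Compound 1 (`COc1ccc(OCCOCCNC2CCCC2)cc1`) gives 99100 nM in a functional assay on SK-OV-3 cells (Homo sapiens) for inhibition, read by CCK-8 assay, with a stated time of 70 h (a higher number here means a weaker inhibitor, a lower number a stronger inhibitor), the highest of three numbers and the weakest inhibitor measured so far. Compound 3 (`COc1cc(OCCOCCNC2CCCC2)ccc1OCc1ccccc1`) gives 44600 nM and compound 2 (`c1ccc(COc2ccc(OCCOCCNc3cc[nH]c3)cc2)cc1`) gives 11300 nM, both lower than compound 1 by more than the scatter. Compound 4 (`COC(=O)c1ccc(COc2ccc(OCCOCCNC3CCCC3)cc2)cc1`) has not yet been measured. It places 4-(methoxycarbonyl)phenyl in place of hydrogen on a saturated chain carbon bound to an oxygen on an aromatic ring.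

Among the compounds with values here, no measured pair isolates this change. Within the data shown here, compound 2 and compound 3 carry an unsubstituted phenyl in that place, but each also differs from compound 1 elsewhere, and no measured compound shows the effect of the methoxycarbonyl group. The closest guide is compound 3 at 44600 nM, which shares the cyclopentyl amine of compound 1. A moderate gain in this assay is therefore expected, beyond the scatter but uncertain in size, with an estimated step of a 4.0-fold lower number from compound 1 to compound 4 (0.60 log units; beyond the scatter). Compound 4 is estimated at 25000 nM, with an expected range of 8000 nM to 70000 nM.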

Compound 4, half-maximal inhibitory concentration: 6990 nM
For compound 4 the middle estimate is 3.6-fold (0.55 log units) above the measured one, outside the stated range (below it).
By their numbers in this assay, from the lowest: compounds 4 and 2 (each within the scatter of the next); then compound 3; then compound 1.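

In this assay, within the data shown here, 4-(methoxycarbonyl)phenyl in place of hydrogen on a saturated chain carbon bound to an oxygen on an aromatic ring gives a 14-fold lower number from compound 1 to compound 4 (1.15 log units; beyond the scatter), the first step that changes only one place. This position therefore accepts a group of 10 heavy atoms, and here that addition comes with a large gain in inhibition rather than a loss. No measurement available here bears on the origin of this gain.

The compounds shown do not separate the contribution of the phenyl ring from that of the methoxycarbonyl group on it, and whether a carboxylic acid, a primary amide or a nitrile in its place would keep the gain remains open. Also open, from the compounds shown here alone, is whether the same change would give a similar step with a different amine on the chain.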